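From compound 3 to compound 4 on the shared core

A few compounds are considered here, and "the series" means these few. Any claim that something is new, unique, unknown or untested is made for them only; others in the source may bear on it.

In a functional assay on KYSE-520 cells for antiproliferative activity against KYSE-520 cell line (Homo sapiens), read by CellTiter-Glo, with a stated time of 24 h (on this read-out higher numbers stand for weaker inhibition and lower numbers for stronger inhibition), compound 1 `C[C@@H]1OCC2(CCN(c3cnc4c(-c5cccc(Cl)c5Cl)n[nH]c4n3)CC2)[C@@H]1N` gives 460 nM and compound 2 `C[C@@H]1OCC2(CCN(c3nc4[nH]nc(-c5ccnc(NC6CCC6)c5Cl)c4c(=O)n3C)CC2)[C@@H]1N` gives 380 nM on the same read-out, while compound 3 `C[C@@H]1OCC2(CCN(c3nc4[nH]nc(Sc5ccnc(N)c5Cl)c4c(=O)n3C)CC2)[C@@H]1N` gives 720 nM here, so compound 3 stands within the scatter of both others. Compound 4 `C[C@@H]1OCC2(CCN(c3nc4[nH]nc(-c5ccncc5)c4c(=O)n3C)CC2)[C@@H]1N` carries pyridin-4-yl in place of (2-amino-3-chloropyridin-4-yl)sulfanyl on an aromatic carbon of the shared core. For the measured compounds named here, no measured pair isolates this change. All three measured compounds carry chlorine on the aromatic group at this place, and compound 4 has none. With compound 3 at 720 nM as the reference, weaker inhibition beyond the scatter is expected. The expected size is the step of a 3.5-fold higher number from compound 3 to compound 4 (0.54 log units; beyond the scatter) towards a higher number. In this assay compound 4 is estimated at 2500 nM with a range from 700 nM to 10000 nM as expected bounds.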

Compound 4, half-maximal inhibitory concentration: 1260 nM
Compound 4: middle estimate off by 2.0-fold (0.30 log units), on the high side; measured number inside the range.
By their numbers in this assay, from the lowest: compounds 2, 1, 3 and 4 (each within the scatter of the next, the first and the last beyond it).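

In this assay, pyridin-4-yl in place of (2-amino-3-chloropyridin-4-yl)sulfanyl on this aromatic carbon gives a 1.8-fold higher number from compound 3 to compound 4 (0.24 log units; within the scatter), although the sulfur link, the chlorine and the amino group all leave together. At this place on the shared core, the larger group and the plain pyridin-4-yl therefore cannot be told apart on this read-out. Nothing measured here bears on the reason for this result. The compounds shown do not separate the contributions of the sulfur link, the chlorine and the amino group. As far as these compounds go, how a methoxy group or a carboxylic acid on the pyridin-4-yl ring would read also remains open.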